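The compounds below may be only part of what the source reports. "The series", "measured", "known", "first", "only" and "open" are said of these compounds alone.

Of the compounds shown here, three sharing one core have been read in a functional assay on HepG2 cells (Homo sapiens) for inhibition, read by MTT assay, with a stated time of 72 h; on this read-out higher numbers stand for weaker inhibition and lower numbers for stronger inhibition. In this assay compound 1 `COc1ccc(-c2cc(C(=O)N3CCC4(CC3)CC(=O)c3nn(C(C)(C)C)cc3O4)c3ccccc3n2)cc1` gives 2780 nM, compound 2 `CC(C)(C)n1cc2c(n1)C(=O)CC1(CCN(C(=O)c3cc(-c4ccncc4)nc4ccccc34)CC1)O2` gives 380 nM, and compound 3 `CC(C)(C)n1cc2c(n1)C(=O)CC1(CCN(C(=O)c3cc(Cl)nc4ccccc34)CC1)O2` gives 4720 nM. Compound 3 thus sits at the weak end of this small set, but it shares that end: the gap is a 1.7-fold higher number from compound 1 to compound 3 (0.23 log units; within the scatter). Its distance to the remaining compound is much greater, at a 12-fold higher number from compound 2 to compound 3 (1.09 log units; beyond the scatter).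

Compound 4 `CCOc1cc(C(=O)N2CCC3(CC2)CC(=O)c2nn(C(C)(C)C)cc2O3)c2ccccc2n1` carries ethoxy in place of chloro on an aromatic carbon, next to the ring nitrogen (ethoxy in place of chloro on an aromatic carbon). Going by the values given here, all the measured steps concern this same carbon, though none of them brings ethoxy there. Swapping 4-methoxyphenyl for chloro made no difference beyond the scatter, whereas pyridin-4-yl stands apart, with a modest 7.3-fold lower number from compound 1 to compound 2 (0.86 log units; beyond the scatter) as well as the large step already noted. Among the compounds with values here, only that one group has moved the number clearly, so no step beyond the scatter is expected in this assay for ethoxy. The step estimated is a 1.5-fold lower number from compound 3 to compound 4 (0.17 log units; within the scatter). Compound 4 is expected at about 3200 nM, with an estimated range of 1100 nM to 9000 nM.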

Compound 4, half-maximal inhibitory concentration: > 10000 nM
Compound 4: a limit, no number (the forecaster's own chance of this, stated with the estimate: 8%); middle value at least 3.1-fold (0.49 log units) from the limit.
By their numbers in this assay, from the lowest: compound 2; then compounds 1 and 3 (each within the scatter of the next). At a limit, above all of these: compound 4.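

In this assay compound 4 reads only as a limit and not as a number: the limit of > 10000 nM in this assay, at which 1 of the 4 values shown sits. Chloro and 4-methoxyphenyl could not be told apart on this aromatic carbon, leaving pyridin-4-yl as the only group that stood out, but ethoxy now separates from both of them, with an at least 2.1-fold higher number from compound 3 to compound 4 (0.32 log units; beyond the scatter) and an at least 3.5-fold higher number from compound 1 to compound 4 (0.55 log units; beyond the scatter). The position therefore responds to a second group, in the opposite direction to pyridin-4-yl, and the two lie far apart, with an at least 26-fold higher number from compound 2 to compound 4 (1.42 log units; beyond the scatter).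

The compounds shown leave open whether the change follows the oxygen joined to the ring or the ethyl part behind it, a question that methoxy, a longer alkoxy chain or an amine on this carbon would help to settle. They also leave open whether the lower number of compound 2 belongs to pyridin-4-yl in particular, or would also appear with pyridin-3-yl or unsubstituted phenyl.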